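Urea series, whole-plant rice activity: methyl to heptyl

This account rests on a few compounds, and the source may have more. Where it says the series, first, only, none or still open, it means among the compounds named here.

Measured so far:
compound 1 `Cc1ccccc1NC(=O)N[C@H](C)c1ccccc1` – 100%
compound 2 `Cc1cccc(NC(=O)N[C@H](C)c2ccccc2)c1` – 98%
compound 3 `Cc1ccc(NC(=O)N[C@H](C)c2ccccc2)cc1` – 98%

In an ADME assay on the whole organism with Oryza sativa as the target, tested at 1 uM (a higher number here means a weaker effect of the compound at the concentration tested, a lower number a stronger effect), compound 1 gives 100%, compound 2 gives 98% and compound 3 gives 98%. Compound 3 stands level with compound 2 at the digits shown, the two together the lowest of the three numbers; compound 1 sits a little higher, within the scatter. All three lie at or near the top of the scale, so moving the methyl around the shared core changes nothing beyond the scatter.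

Compound 4 `CCCCCCCc1ccc(NC(=O)N[C@H](C)c2ccccc2)cc1` is to be measured. It differs from compound 3 by hexyl in place of hydrogen on a saturated chain carbon bound to an aromatic carbon. Among the compounds with values here, no step between measured compounds is available to size this change; the three numbers only show that the position of a methyl leaves the read-out unchanged, and the present change is larger than any in the set. For compound 4 a step in this assay of a number 8 percentage points lower from compound 3 to compound 4 (within the scatter) is expected, downward but within the scatter. Compound 4 is estimated at 90%, within 65% to 100%.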

Compound 4, a percentage reported as activity, at one concentration (the size of the read-out at that concentration, not a potency): 100%
The estimate for compound 4 lay 10 percentage points below the measured number, and the stated range covers the measured number.
By their numbers in this assay, from the lowest: compounds 2, 3, 1 and 4 (each within the scatter of the next).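

In this assay, hexyl in place of hydrogen on the saturated chain carbon bound to an aromatic carbon gives a number 2 percentage points higher from compound 3 to compound 4 (within the scatter). The earlier compounds shown here covered only the placing of a methyl; this result shows that methyl to heptyl, a much larger change at this place, also stays within the scatter and leaves the read-out at the top of the scale. No supporting measurement bears on this result.

On these data alone, whether an amine or a carboxylic acid at the end of this chain would move the read-out remains open. So does whether any change to the shared core gives a step beyond the scatter.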